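Ortho substituent swap on the chalcone aryl ring

The compounds below may be only part of what the source reports. "The series", "measured", "known", "first", "only" and "open" are said of these compounds alone.

Compound 3 `O=C(COc1ccc(C(=O)/C=C/c2ccccc2Br)cc1)N[C@H]1CCOC1=O` gives 12200 nM in a functional assay on MGC-803 cells (Homo sapiens) for antiproliferative activity, read by MTT assay, with a stated time of 72 h (on this read-out higher numbers stand for weaker inhibition and lower numbers for stronger inhibition), and holds the lowest of the two numbers in the series. Its nearest neighbour is compound 1 `O=C(COc1ccc(C(=O)/C=C/c2ccccc2Cl)cc1)N[C@H]1CCOC1=O`, which gives 27100 nM; the step of a 2.2-fold lower number from compound 1 to compound 3 (0.35 log units; beyond the scatter) is modest. Compound 2 `CCOc1ccccc1OCCSC(=S)N[C@H]1CCOC1=O`, a different scaffold, reaches only the limit of this assay, > 64000 nM, and so sits at the limit of > 64000 nM in this assay, at which 1 of the 3 values shown sits.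

Compound 4 `COc1ccccc1/C=C/C(=O)c1ccc(OCC(=O)N[C@H]2CCOC2=O)cc1` differs from compound 3 by methoxy in place of bromo on an aromatic carbon. Among the measured compounds shown here, the only measured step, from the chloro to the bromo analogue, changes one halogen for another and does not reach the methoxy case, so it bears on the new change only loosely; it shows that a change at this ring position gives a modest movement in this assay. The loss of the halogen may cost some activity, but no shown step settles that. For compound 4 the step of a 1.8-fold higher number from compound 3 to compound 4 (0.26 log units; within the scatter) is expected, in the weaker direction and near the scatter. Compound 4 is therefore estimated at 22000 nM, with a range from 8000 nM to 60000 nM.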

Compound 4, half-maximal inhibitory concentration: 39400 nM
Compound 4: middle estimate off by 1.8-fold (0.25 log units), on the low side; the measured number falls inside the stated range.
By their numbers in this assay, from the lowest: compound 3; then compounds 1 and 4 (each within the scatter of the next). At a limit, above all of these: compound 2.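

In this assay, replacing bromo with methoxy on this aromatic carbon, ortho to a large group, gives a 3.2-fold higher number from compound 3 to compound 4 (0.51 log units; beyond the scatter), so this position distinguishes these two groups, though only modestly. The same methoxy group does not separate from chloro: the comparison gives a 1.5-fold higher number from compound 1 to compound 4 (0.16 log units; within the scatter), which leaves bromo as the only one of the three groups shown to stand apart from both others at this position. No measured property shown here accounts for either step.

From the compounds shown here alone, it remains open whether an amine or a carboxylic acid in place of bromo would read with compound 3 or with compound 1 and compound 4. A fluoro or ethoxy group would also test whether the separation of bromo from chloro and methoxy extends beyond these three compounds.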